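Adding a Third Methoxy Group to Compound 2

This account rests on a few compounds, and the source may have more. Where it says the series, first, only, none or still open, it means among the compounds named here.

Three compounds have been measured:
Compound 1, `Nc1cc(N)c2nc(-c3ccccc3)c(NCc3ccc(Cl)c(Cl)c3)nc2c1`, gives 2040 nM.
Compound 2, `COc1ccc(CNc2nc3cc(N)cc(N)c3nc2-c2ccccc2)cc1OC`, gives 2690 nM.
Compound 3, `CCOC(=O)[C@H](CCC(=O)O)NC(=O)c1ccc(Sc2nc3cc(N)cc(N)c3nc2-c2ccccc2)cc1`, gives 21400 nM.

All three share a core, and the numbers come from a functional assay on NCI-H522 cells (Homo sapiens) for inhibition, read by sulforhodamine B assay, with a stated time of 48 h; a higher number here means a weaker inhibitor of growth, a lower number a stronger inhibitor of growth. Compound 2 holds the second highest of the three numbers: its nearest neighbour is compound 1, which lies within the scatter, while compound 3 sits far beyond the scatter on the higher side.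

Compound 4, `COc1cc(CNc2nc3cc(N)cc(N)c3nc2-c2ccccc2)cc(OC)c1OC`, has not yet been measured. It differs from compound 2 in a single place: methoxy in place of hydrogen on an aromatic carbon.

Going by the values given here, only one measured step touches the same part of the molecule, the exchange of the whole aromatic group at the end of the chain, a 1.3-fold higher number from compound 1 to compound 2 (0.12 log units; within the scatter). That exchange left the number essentially unchanged. Among the compounds with values here, no measured pair shows what adding one further methoxy group to that ring does, so the expectation rests on the small size of the only related step. The change is therefore expected to produce no step beyond the scatter in this assay, in either direction, which means a step of a 1.1-fold higher number from compound 2 to compound 4 (0.05 log units; within the scatter).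

The estimate for compound 4 is 3000 nM, expected to fall between 1200 nM and 7500 nM.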

Compound 4, concentration for 50% growth inhibition: < 50200 nM
Compound 4 was reported as a limit (the forecaster's own chance of this, stated with the estimate: 3%); the middle value lies beyond the limit too.
By their numbers in this assay, from the lowest: compounds 1 and 2 (each within the scatter of the next); then compound 3.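

In this assay compound 4 gives < 50200 nM, which is a limit and not a number. The step from compound 2 to compound 4 therefore cannot be read. The compounds shown leave open whether methoxy in place of hydrogen on this aromatic carbon changes the read-out at all, and in which direction.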